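Replacing the Nitrophenyl Group of Compound 2

The source may report more compounds than this note shows. Statements on the series, on what has been measured and on what is new or still open speak of the compounds shown alone.

In an ADME assay on MT4 cells (Homo sapiens) for cytotoxicity, read by MTT assay (a higher number here means that more compound is tolerated, a lower number that less compound is tolerated), compound 1 `O=C1c2ccccc2C(=O)N1CCOC(=S)N(C(=O)c1cccc([N+](=O)[O-])c1)c1ccc(Cl)cc1` gives 18000 nM and compound 2 `Cc1ccc(N(C(=O)c2cccc([N+](=O)[O-])c2)C(=S)OCCN2C(=O)c3ccccc3C2=O)cc1` gives 100000 nM. Compound 3 `O=C1c2ccccc2C(=O)N1CCOC(=S)N(C(=O)c1cccc(F)c1F)c1ccc(Cl)cc1` gives 58000 nM, within the usual scatter of compound 2. Compound 4 `Cc1ccc(N(C(=O)c2ccc(F)cc2F)C(=S)OCCN2C(=O)c3ccccc3C2=O)cc1` differs from compound 2 by one exchange: 2,4-difluorophenyl in place of 3-nitrophenyl on a carbonyl carbon. The step of a 5.6-fold higher number from compound 1 to compound 2 (0.74 log units; beyond the scatter) came from methyl in place of chloro, so it does not involve this exchange. The closer guide is a 3.2-fold higher number from compound 1 to compound 3 (0.51 log units; beyond the scatter), from 2,3-difluorophenyl in place of 3-nitrophenyl on a carbonyl carbon. That modest rise involved a different difluorophenyl group and a chloro compound, so only part of it is expected to carry over. The expected change is a 1.5-fold higher number from compound 2 to compound 4 (0.18 log units; within the scatter). Compound 4 is estimated at 150000 nM, with an expected range of 50000 nM to 350000 nM.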

Compound 4, half-maximal cytotoxic concentration: 20000 nM
Compound 4: middle estimate off by 7.5-fold (0.88 log units), on the high side, and the stated range ends above it.
By their numbers in this assay, from the lowest: compounds 1 and 4 (each within the scatter of the next); then compounds 3 and 2 (each within the scatter of the next).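

In this assay, the exchange of 3-nitrophenyl for 2,4-difluorophenyl on this carbonyl carbon gives a 5.0-fold lower number from compound 2 to compound 4 (0.70 log units; beyond the scatter). The earlier exchange to 2,3-difluorophenyl, in the chloro pair, went the other way with a 3.2-fold higher number from compound 1 to compound 3 (0.51 log units; beyond the scatter), so leaving 3-nitrophenyl has no single direction across these compounds. Nothing available explains this difference.

Still open, from the compounds shown here alone, is whether the opposite directions follow the two fluorine patterns or the methyl and chloro groups. Going by these compounds, how a plain phenyl group or an amine-bearing phenyl group would read on this carbonyl carbon also remains open.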